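The source may hold more compounds than are shown below. What is called first, only, known or untested is meant among the compounds shown, and "the series" means these compounds.

In a functional assay on MCF7 cells (Homo sapiens) for cytotoxicity, read by MTT assay, with a stated time of 48 h (on this read-out higher numbers stand for weaker inhibition of growth and lower numbers for stronger inhibition of growth), compound 1 (`FC(F)(F)c1nc2cc(Cl)c(Cl)cc2n1CC1CC1`) gives 60200 nM and compound 2 (`Nc1ccccc1Cn1c(C(F)(F)F)nc2cc(Cl)c(Cl)cc21`) gives 55600 nM on the same test. For the measured compounds named here, the single measured step is a 1.1-fold lower number from compound 1 to compound 2 (0.03 log units; within the scatter) and so the two numbers cannot be told apart, which leaves compound 2 level with the only other compound tested.

Going by the values given here, compound 3 (`Nc1cccc(Cn2c(C(F)(F)F)nc3cc(Cl)c(Cl)cc32)c1`) has the same atoms as compound 2, joined differently, with 3-aminophenyl in place of 2-aminophenyl on a saturated chain carbon bound to an aromatic nitrogen as the only change. Just one measured step bears on this. At that same carbon, 2-aminophenyl took the place of cyclopropyl and the number stayed within the scatter, as a 1.1-fold lower number from compound 1 to compound 2 (0.03 log units; within the scatter) shows. Among the compounds with values here, no compound carrying 3-aminophenyl has been measured, so this guide is indirect. A step beyond the scatter is therefore not expected in this assay in either direction. The expected step is a 1.1-fold lower number from compound 2 to compound 3 (0.05 log units; within the scatter) and no larger. For compound 3 the estimated value is 50000 nM with an expected range from 20000 nM to 100000 nM across repeat measurements.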

Compound 3, concentration for 50% growth inhibition: 77500 nM
Compound 3: middle estimate off by 1.6-fold (0.19 log units), on the low side, and the stated range covers the measured number.
By their numbers in this assay, from the lowest: compounds 2, 1 and 3 (each within the scatter of the next).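

Moving the amine within the ring, with 3-aminophenyl in place of 2-aminophenyl on the saturated chain carbon bound to an aromatic nitrogen, stays within the scatter in this assay (a 1.4-fold higher number from compound 2 to compound 3 (0.14 log units; within the scatter)), so this test does not separate the two arrangements of the same atoms. Setting 3-aminophenyl in place of cyclopropyl at that carbon also stays within the scatter (a 1.3-fold higher number from compound 1 to compound 3 (0.11 log units; within the scatter)), which means that cyclopropyl and both aminophenyl groups now give numbers that cannot be told apart, even though a saturated ring and an aromatic ring carrying an amine are quite different groups. Nothing available beyond these growth-inhibition numbers bears on why the three compounds sit so close together.

From the compounds shown here alone, it remains open whether any group at this carbon can move the number beyond the scatter, and a plain phenyl would show whether the amine matters at all, while a carboxylic acid or a hydroxyl in place of that amine would test other replacements on the ring. Going by these compounds, the three compounds also share the rest of their structure, so the effect of replacing the trifluoromethyl group or either chlorine on the shared core remains unknown.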